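Pyridin-3-yl to pyridin-4-yl on compound 1

This account rests on a few compounds, and the source may have more. Where it says the series, first, only, none or still open, it means among the compounds named here.

In a functional assay on QGY-7703 cells (Homo sapiens) for cytotoxicity, read by MTT assay, with a stated time of 24 h (a lower number here means a stronger inhibitor, a higher number a weaker inhibitor), compound 1 `CN1C/C(=C\c2ccc(C(F)(F)F)cc2)C(=O)/C(=C/c2cccnc2)C1` gives 1660 nM, the lower of the two actual numbers available. The nearest is compound 3 `CN1C/C(=C\c2ccncc2)C(=O)/C(=C/c2ccc(F)cc2Br)C1` at 6900 nM, a higher number with a gap beyond the scatter. Compound 2 `CN1C/C(=C\c2ccc(C#N)cc2)C(=O)/C(=C/c2cccnc2)C1` is reported only as a limit of the assay, > 20000 nM.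

The next compound to be tested is compound 4 `CN1C/C(=C\c2ccncc2)C(=O)/C(=C/c2ccc(C(F)(F)F)cc2)C1`, which has the same atoms as compound 1 joined differently, with pyridin-4-yl in place of pyridin-3-yl on a double-bonded chain carbon bound to a double-bonded ring carbon. Within the data shown here, the only measured step, cyano in place of trifluoromethyl on an aromatic carbon, is large: an at least 12-fold higher number from compound 1 to compound 2 (1.08 log units; beyond the scatter). It lies at another place in the molecule, however, so it sets no size for this change. Compound 3 also carries pyridin-4-yl, but its other group differs as well, so its 6900 nM gives only a weak hint towards a higher number. The expected change in this assay is a 1.4-fold higher number from compound 1 to compound 4 (0.14 log units; within the scatter), which would not lie beyond the scatter. Compound 4 is estimated at 2300 nM, with an expected range of 700 nM to 7500 nM.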

Compound 4, half-maximal inhibitory concentration: 10400 nM
Beside the measured number, compound 4's estimate is 4.5-fold (0.66 log units) below it; the whole stated range lies below it.
By their numbers in this assay, from the lowest: compound 1; then compounds 3 and 4 (each within the scatter of the next). At a limit, above all of these: compound 2.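

In this assay, pyridin-4-yl in place of pyridin-3-yl on a double-bonded chain carbon bound to a double-bonded ring carbon gives a 6.3-fold higher number from compound 1 to compound 4 (0.80 log units; beyond the scatter). This is the first step shown at this place, and it shows that the place responds even when the entering and leaving groups match in heavy atoms, hydrogen-bond donors, hydrogen-bond acceptors and net charge, so that only the way the atoms are joined differs. The compounds shown offer no measurement that explains this step.

The compounds shown leave open how pyridin-2-yl or an unsubstituted phenyl ring would read at this place with the trifluoromethyl-bearing ring kept as it is in compound 1. As far as these compounds go, compound 2 gives > 20000 nM, which is a limit and not a number, so it remains open whether the change from pyridin-3-yl to pyridin-4-yl would have a similar size with cyano in place of trifluoromethyl.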